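The compounds below may be only part of what the source reports. "The series", "measured", "known", "first", "only" and "open" are said of these compounds alone.

In a functional assay on KB cells (Homo sapiens) for cytotoxicity, read by sulforhodamine B assay (on this read-out lower numbers stand for stronger inhibition and higher numbers for weaker inhibition), compound 1 `C=C1[C@@H](OC(C)=O)C[C@@H]2[C@](C)(CO[Si](C)(C)C(C)(C)C)[C@H](OC(C)=O)CC[C@@]2(C)[C@@H]1C[C@@H](Nc1ccc(OC)c(OC)c1)C1=CCOC1=O` gives 5800 nM, the lowest number available. Compound 2 `C=C1[C@@H](OC(C)=O)C[C@@H]2[C@](C)(COC=O)[C@H](OC(C)=O)CC[C@@]2(C)[C@@H]1C[C@@H](Nc1ccc(O)cc1)C1=CCOC1=O` gives 28900 nM, a higher number. Compound 3 `C=C1[C@@H](OC(C)=O)C[C@@H]2[C@](C)(COC=O)[C@H](OC(C)=O)CC[C@@]2(C)[C@@H]1C[C@@H](Nc1ccc(OC)c(OC)c1)C1=CCOC1=O` is recorded only as a limit, > 50000 nM.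

Compound 4 `C=C1[C@@H](OC(C)=O)C[C@@H]2[C@](C)(CO[Si](C)(C)C(C)(C)C)[C@H](OC(C)=O)CC[C@@]2(C)[C@@H]1C[C@@H](Nc1ccccc1)C1=CCOC1=O` differs from compound 1 only on the amine nitrogen: phenyl in place of 3,4-dimethoxyphenyl on an amine nitrogen. In words, it carries phenyl in place of 3,4-dimethoxyphenyl on an amine nitrogen.

The closest measured change sits at the same place, with an at least 1.7-fold higher number from compound 2 to compound 3 (0.23 log units; that floor lies within the scatter). Its floor lies within the scatter, and it exchanges a different pair of groups, so it gives only weak guidance. The other measured step, an at least 8.6-fold higher number from compound 1 to compound 3 (0.93 log units; beyond the scatter), is beyond the scatter, but it concerns the group on an oxygen on a saturated carbon, which compound 4 keeps unchanged from compound 1.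

No step beyond the scatter is therefore expected in this assay, and neither direction is favoured. The expected step is a 1.0-fold higher number from compound 1 to compound 4 (0.01 log units; within the scatter). For compound 4 the estimated value is 6000 nM, with an expected range of 2000 nM to 20000 nM.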

Compound 4, half-maximal inhibitory concentration: 5710 nM
Estimate against measurement, compound 4: 1.1-fold (0.02 log units) above; measured number inside the range.
By their numbers in this assay, from the lowest: compounds 4 and 1 (each within the scatter of the next); then compound 2. At a limit, above all of these: compound 3.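

With the rest of compound 1 kept, phenyl in place of 3,4-dimethoxyphenyl on the amine nitrogen gives a 1.0-fold lower number from compound 1 to compound 4 (0.01 log units; within the scatter) in this assay, so in this setting the 3,4-dimethoxyphenyl group is not needed to hold the number. Among these compounds, this is the only step at this place with a measured number at both ends, whereas the earlier one, an at least 1.7-fold higher number from compound 2 to compound 3 (0.23 log units; that floor lies within the scatter), gives only a floor. Compound 3 is recorded only as a limit: the limit of > 50000 nM in this assay, at which 1 of the 4 values shown sits.

The compounds shown leave open whether any group on this nitrogen can move the number beyond the scatter, for instance a benzyl or pyridyl group in place of phenyl. As far as these compounds go, it also remains open whether 4-hydroxyphenyl would behave as phenyl does on the core of compound 1.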